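A few compounds are considered here, and "the series" means these few. Any claim that something is new, unique, unknown or untested is made for them only; others in the source may bear on it.

Compound 1 `COc1ccc(-c2cc(C(=O)NC3CCCCCC3)c(OCc3ccc(F)cc3)nc2C)cc1`: > 10000 nM
Compound 2 `Cc1c(Cl)cc(C(=O)NC2CCCCCC2)c(=O)n1Cc1ccc(F)cc1`: 5900 nM

In an assay on U-937 cells for inhibition of Fatty-acid amide hydrolase 1 (Homo sapiens), read by scintillation counting, with a stated time of 15 min (on this read-out lower numbers stand for stronger inhibition and higher numbers for weaker inhibition), compound 1 reaches only a limit of the assay, > 10000 nM, so no number is known for it. Compound 2, built on a different core, gives 5900 nM in this assay. Compound 3 `Cc1nc(OCc2ccc(F)cc2)c(C(=O)NC2CCCCCC2)cc1Br` differs from compound 1 by bromo in place of 4-methoxyphenyl on an aromatic carbon. Since compound 1 sits at a limit (the limit of > 10000 nM in this assay, at which 1 of the 2 values shown sits), the size of this step cannot be fixed; a shift toward stronger inhibition is expected from compound 1 to compound 3, an at least 1.4-fold lower number from compound 1 to compound 3 (0.15 log units; that floor lies within the scatter), though it may not exceed the usual scatter. Compound 3 is estimated at 7000 nM, between 2500 nM and 20000 nM, with a fair chance that the assay again reports only a limit.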

Compound 3, half-maximal inhibitory concentration: > 10000 nM
Compound 3: only a limit was reported; the forecaster's own chance of this, stated with the estimate: 40%; middle value at least 1.4-fold (0.15 log units) from the limit.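

In this assay, compound 1 and compound 3 both stop at a limit, so the step between them cannot be read: the limit of > 10000 nM in this assay, at which 2 of the 3 values shown sit.

Going by these compounds, whether bromo or 4-methoxyphenyl gives stronger inhibition on this core, and by how much, stays open.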